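A few compounds are considered here, and "the series" means these few. Any claim that something is new, unique, unknown or untested is made for them only; others in the source may bear on it.

Compound 1, whose structure is `COc1cc(CNC(=O)/C=C/c2ccccc2OCc2nc(C)c(C)nc2C)ccc1O`, is a cinnamide bearing a free hydroxy group on one aromatic ring. In a functional assay on SH-SY5Y cells (Homo sapiens) for cytotoxicity, read by MTT assay, with stated times of 24 h and 4 h (a higher number here means that more compound is needed for the effect, a lower number that less compound is needed), compound 1 gives 12000 nM. Compound 2, with the structure `COc1cc(CNC(=O)/C=C/c2ccccc2OCc2nc(C)c(C)nc2C)ccc1OCc1nc(C)c(C)nc1C`, differs from compound 1 by (3,5,6-trimethylpyrazin-2-yl)methyl in place of hydrogen on an oxygen on an aromatic ring. In this assay compound 2 gives 6280 nM, so the step of a 1.9-fold lower number from compound 1 to compound 2 (0.28 log units; within the scatter) is a modest one.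

Compound 3, with the structure `COc1cc(CNC(=O)/C=C/c2cc(OC)c(OC)c(OC)c2)ccc1O`, keeps the free hydroxy group but carries a different core on the cinnamide side; how the cores of compound 1 and compound 3 differ is not broken down here. In this assay compound 3 gives 5910 nM, which sits close to the number for compound 2 and is a somewhat lower number than that of compound 1.

Compound 4, with the structure `COc1cc(CNC(=O)/C=C/c2cc(OC)c(OC)c(OC)c2)ccc1OCc1nc(C)c(C)nc1C`, has not yet been measured. It differs from compound 3 by (3,5,6-trimethylpyrazin-2-yl)methyl in place of hydrogen on an oxygen on an aromatic ring. The place where this group enters is described in the same words for both pairs. This is the same change as that from compound 1 to compound 2.

Resting on the step of a 1.9-fold lower number from compound 1 to compound 2 (0.28 log units; within the scatter), which stayed within the usual scatter, the expected step from compound 3 to compound 4 is likewise small, estimated as a 1.7-fold lower number from compound 3 to compound 4 (0.23 log units; within the scatter). Compound 4 is therefore expected to give about 3500 nM in this assay, with a range estimated from 1500 nM to 9000 nM.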

Compound 4, half-maximal effective concentration: 11500 nM
The estimate for compound 4 lay 3.3-fold (0.52 log units) below the measured number, outside the stated range (above it).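

Placing the (3,5,6-trimethylpyrazin-2-yl)methyl group on the oxygen of the free hydroxy group gives a 1.9-fold higher number from compound 3 to compound 4 (0.29 log units; within the scatter) in this assay, and this does not match what the same change did on the other core: the same change on two cores in this assay, a 1.9-fold lower number (0.28 log units; within the scatter) from compound 1 to compound 2 and a 1.9-fold higher number (0.29 log units; within the scatter) from compound 3 to compound 4, 3.7-fold (0.57 log units) apart, beyond the scatter of two such steps. Each step taken alone is small, but the two run in opposite directions and the gap between them is larger than repeat measurements would be expected to produce, so in this series the outcome of this change on the core of compound 1 cannot simply be carried over to the core of compound 3. These two pairs do not show why the cores respond differently, they give no rule for any further core, and neither step alone is firm evidence that the change truly alters the number on its own core.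

The compounds shown leave open how a different group on the same oxygen, such as a benzyl group or a chain ending in an amine or a carboxylic acid, would behave on these two cores. They also leave open whether a third core would follow the core of compound 1, the core of compound 3, or neither.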